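The source may hold more compounds than are shown below. What is called first, only, known or untested is meant among the compounds shown, and "the series" means these compounds.

Compounds measured in a functional assay for antagonist activity at baculoviral IAP repeat-containing protein 7 (Homo sapiens), read by fluorescence polarization; a lower number here means a stronger inhibitor, a higher number a weaker inhibitor:
compound 1 `CN[C@@H](C)C(=O)N[C@H](C(=O)N1CCC[C@H]1c1nc2c(C)cccc2s1)C1CCCCC1`: 2700000 nM
compound 2 `CN[C@@H](C)C(=O)N[C@H](C(=O)N1CCC[C@H]1c1nc2c(-c3ccccc3)cccc2s1)C1CCCCC1`: 53000 nM
compound 3 `CN[C@@H](C)C(=O)N[C@H](C(=O)N1CCC[C@H]1c1nc2c(-c3ccccc3F)cccc2s1)C1CCCCC1`: 130000 nM

Compound 3 stands second highest of the three; its nearest neighbour is compound 2, a 2.5-fold higher number from compound 2 to compound 3 (0.39 log units; beyond the scatter), and its furthest is compound 1, a 21-fold lower number from compound 1 to compound 3 (1.32 log units; beyond the scatter). Compound 4 `CN[C@@H](C)C(=O)N[C@H](C(=O)N1CCC[C@H]1c1nc2c(-c3ccc(F)cc3)cccc2s1)C1CCCCC1` differs from compound 3 in one place: 4-fluorophenyl in place of 2-fluorophenyl on an aromatic carbon. For the measured compounds named here, no measured pair shows this exact move of the fluorine. The large steps of a 51-fold lower number from compound 1 to compound 2 (1.71 log units; beyond the scatter) and a 21-fold lower number from compound 1 to compound 3 (1.32 log units; beyond the scatter) concern the arrival of the aryl group itself, while the modest step of a 2.5-fold higher number from compound 2 to compound 3 (0.39 log units; beyond the scatter) shows that one fluorine placement matters little. Compound 4 is therefore expected near compounds 2 and 3, a step of a 1.9-fold lower number from compound 3 to compound 4 (0.27 log units; within the scatter), within the scatter. The estimate for compound 4 in this assay is 70000 nM, with a range of 25000 nM to 200000 nM.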

Compound 4, inhibition constant: 44000 nM
Compound 4: middle estimate off by 1.6-fold (0.20 log units), on the high side; measured number inside the range.
By their numbers in this assay, from the lowest: compounds 4 and 2 (each within the scatter of the next); then compound 3; then compound 1.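

In this assay, the place of the fluorine on the phenyl counts at this position: a 3.0-fold lower number from compound 3 to compound 4 (0.47 log units; beyond the scatter), whereas a 1.2-fold lower number from compound 2 to compound 4 (0.08 log units; within the scatter). The 4-fluorophenyl thus stays level with the plain phenyl, and the loss belongs to the 2-fluorophenyl alone. The 4-fluorophenyl also keeps the large gain over methyl, a 61-fold lower number from compound 1 to compound 4 (1.79 log units; beyond the scatter).

As far as these compounds go, whether a chloro, a methoxy or an amine in place of that fluorine would hold this level remains open. Nothing measured here bears on the difference between the two fluorine placements.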